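The source may hold more compounds than are shown below. What is called first, only, known or untested is meant among the compounds shown, and "the series" means these compounds.

Compound 1 `Cc1nc(-c2ccc(C(F)(F)F)cc2)sc1CNc1ccc(OCC(=O)O)cc1` is the stronger of the two measured compounds. In a functional assay on CHO cells for agonist activity at Free fatty acid receptor 1 (Homo sapiens), read by a luciferase reporter (on this read-out higher numbers stand for larger maximal responses and lower numbers for smaller maximal responses), compound 1 reaches 100%, the highest of the two numbers seen here. Compound 2 `O=C(O)[C@@H]1C[C@H]1c1ccc(NCc2cccc(Oc3ccccc3)c2)cc1`, built on a different core and carrying its acid on a cyclopropyl ring, reaches in this assay 64%, a gap to compound 1 that lies beyond the scatter. Compound 3 `Cc1nc(-c2ccc(C(F)(F)F)cc2)sc1CNc1ccc([C@H]2C[C@@H]2C(=O)NO)cc1` has not yet been measured. It keeps the core of compound 1 and differs from it in one place, (2-(hydroxycarbamoyl)cyclopropyl in place of carboxymethoxy on an aromatic carbon). The carboxymethoxy leaves and the 2-(hydroxycarbamoyl)cyclopropyl enters, so the acid is exchanged for a hydroxamic group held on a three-membered ring. Among the measured compounds shown here, no measured pair shows this exchange, so the expected step is uncertain. A downward step is expected in this assay, a number 40 percentage points lower from compound 1 to compound 3 (beyond the scatter), beyond the scatter. For compound 3 the maximal response is estimated at 60%, within a range from 30% to 90%.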

Compound 3, largest response reached (reported as percent of maximum), in percent of the reference or control that the assay uses: 78%
For compound 3 the middle estimate is 18 percentage points below the measured one, and the stated range covers the measured number.
By their numbers in this assay, from the lowest: compound 2; then compound 3; then compound 1.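

In this assay, the step is a number 22 percentage points lower from compound 1 to compound 3 (beyond the scatter), so replacing carboxymethoxy with 2-(hydroxycarbamoyl)cyclopropyl at this aromatic carbon, para to a large group, lowers the maximal response without abolishing it. Compound 3 still gives 78%, which shows that on the core of compound 1 this position can carry a hydroxamic group on a three-membered ring in place of a carboxylic acid and still produce a clear response. Nothing available here explains why the response falls.

The ring and the hydroxamic group enter together, so their separate contributions cannot be told apart. On the same core, a 2-carboxycyclopropyl group would keep the ring and restore the acid, while a hydroxamic acid on an open chain, such as hydroxycarbamoylmethoxy, would keep the hydroxamic group without the ring.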